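The source may hold more compounds than are shown below. What is called first, only, known or untested is meant among the compounds shown, and "the series" means these compounds.

Working notes on a series built on one shared core, varied at a single aromatic carbon. Compound 1 `C[S+]([O-])c1c(F)c(N)c2c(=O)cc(-c3ccc(N)c(F)c3)oc2c1F` is the weakest of the three measured: in a functional assay on MCF7 cells (Homo sapiens) for cytotoxicity, read by neutral red uptake, with a stated time of 3 days (on this read-out lower numbers stand for stronger inhibition and higher numbers for weaker inhibition), compound 1 gives 2500 nM. Compound 2 `Nc1ccc(-c2cc(=O)c3c(N)c(F)c(N)c(F)c3o2)cc1F` carries an amino group at that carbon and gives 7.7 nM, the step being a 320-fold lower number from compound 1 to compound 2 (2.51 log units; beyond the scatter). Compound 3 `CN(C)CCC(=O)OCc1c(F)c(N)c2c(=O)cc(-c3ccc(N)c(F)c3)oc2c1F` carries the (((2-(dimethylamino)ethyl)carbonyl)oxy)methyl group there and gives 19 nM; against the other two this reads a 130-fold lower number from compound 1 to compound 3 (2.12 log units; beyond the scatter) and a 2.5-fold higher number from compound 2 to compound 3 (0.39 log units; beyond the scatter). Going by the values given here, on the numbers so far compound 3 stands second of three, close to compound 2 and far from compound 1.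

Compound 4 `CCCOCc1c(F)c(N)c2c(=O)cc(-c3ccc(N)c(F)c3)oc2c1F` differs from compound 3 in one place: propyl in place of (2-(dimethylamino)ethyl)carbonyl on an oxygen on a saturated carbon. The saturated carbon and the oxygen on it stay; only what sits on that oxygen changes. Among the compounds with values here, no measured step exchanges one substituent on that oxygen for another, so none bears on this change directly. What the measured steps do show is that the large gaps all involve the group of compound 1, while compounds 2 and 3, which differ in what sits on the same carbon, lie only a modest step apart. A step of at most similar size is therefore expected here, leaning toward a weaker number: a 1.8-fold higher number from compound 3 to compound 4 (0.27 log units; within the scatter). Compound 4 is estimated at 35 nM, with the expected range for compound 4 running from 8 nM to 160 nM.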

Compound 4, half-maximal inhibitory concentration: 1200 nM
The estimate for compound 4 lay 34-fold (1.54 log units) below the measured number, outside the stated range (above it).
By their numbers in this assay, from the lowest: compound 2; then compound 3; then compound 4; then compound 1.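

In this assay, going by these compounds alone, the saturated carbon and its oxygen stay in place, yet what sits on that oxygen decides a large part of the outcome (a 63-fold higher number from compound 3 to compound 4 (1.80 log units; beyond the scatter)); the earlier compounds showed no change at this oxygen. The large gaps are also no longer confined to the group of compound 1: propoxymethyl on the aromatic carbon stands far from amino (a 160-fold higher number from compound 2 to compound 4 (2.19 log units; beyond the scatter)) but only a modest step from the group of compound 1 (a 2.1-fold lower number from compound 1 to compound 4 (0.32 log units; beyond the scatter)), so the four compounds fall into a lower pair, compound 2 and compound 3, and a higher pair, compound 1 and compound 4. Nothing at hand accounts for the loss on going from the (2-(dimethylamino)ethyl)carbonyl group to propyl.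

The step changes the carbonyl and the dimethylamino group together, so the compounds shown do not say which of them, if either, goes with the lower number of compound 3. An acetyl group or a 2-(dimethylamino)ethyl chain on the same oxygen would separate the two, and a free hydroxymethyl on the aromatic carbon would show where the bare oxygen stands.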